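Semicarbazide extension of the chloro urea in the L1210 series

The compounds below may be only part of what the source reports. "The series", "measured", "known", "first", "only" and "open" are said of these compounds alone.

Compound 2 `COc1cc(NC(C)CCCNC(=O)Nc2cccc(Cl)c2)c2ncccc2c1` gives 17000 nM in a functional assay on L1210 cells (Mus musculus) for inhibition, read by MTT assay, with a stated time of 72 h (on this read-out lower numbers stand for stronger inhibition and higher numbers for weaker inhibition), the lowest number among the three measured compounds. Compound 1 `COc1cc(NC(C)CCCNC(=O)Nc2cccc(F)c2)c2ncccc2c1` gives 19000 nM; the step of a 1.1-fold lower number from compound 1 to compound 2 (0.05 log units; within the scatter) is within the scatter, so the two are not separated. Compound 3 `COc1cc(NC(C)CCCNC(=O)NNC(=O)Nc2ccc(Br)cc2)c2ncccc2c1` gives 51000 nM and sits furthest from compound 2.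

The next compound, compound 4 `COc1cc(NC(C)CCCNC(=O)NNC(=O)Nc2cccc(Cl)c2)c2ncccc2c1`, differs from compound 2 in one place: ((3-chlorophenyl)carbamoyl)amino in place of 3-chlorophenyl on an amide-type nitrogen.

Among the compounds with values here, two measured steps bear on this change. The step of a 2.7-fold higher number from compound 1 to compound 3 (0.43 log units; beyond the scatter) and the step of a 3.0-fold higher number from compound 2 to compound 3 (0.48 log units; beyond the scatter) both insert a carbamoylamino link between the urea and the halogenated aryl ring, each combined with a change of halogen and of its place on the ring; both weakened inhibition to a modest degree. The halogen swap on its own, seen in the step from compound 1 to compound 2, is within the scatter. The inserted link is the part of the change that the two steps share. The same link enters in compound 4, with the 3-chlorophenyl retained, so a modest rise in the number is expected for compound 4, on the order of a 2.9-fold higher number from compound 2 to compound 4 (0.47 log units; beyond the scatter).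

Compound 4 is therefore expected to give about 50000 nM in this assay, with a likely range from 25000 nM to 100000 nM.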

Compound 4, half-maximal inhibitory concentration: 27000 nM
Estimate against measurement, compound 4: 1.9-fold (0.27 log units) above, within the range that was stated.
By their numbers in this assay, from the lowest: compounds 2, 1, 4 and 3 (each within the scatter of the next, the first and the last beyond it).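

Working notes on the link: in this assay, with 3-chlorophenyl kept on both sides, ((3-chlorophenyl)carbamoyl)amino on the amide-type nitrogen gives a 1.6-fold higher number from compound 2 to compound 4 (0.20 log units; within the scatter) and so is not separated from 3-chlorophenyl, a reading the earlier steps could not give, as each of them changed the link and the halogen together. The comparison with the fluoro urea gives a 1.4-fold higher number from compound 1 to compound 4 (0.15 log units; within the scatter) and the comparison with the bromo compound gives a 1.9-fold lower number from compound 3 to compound 4 (0.28 log units; within the scatter) so that compound 4 lies within the scatter of all three other compounds, and the gaps from compound 1 and compound 2 to compound 3 cannot be assigned on these values to the link alone or to the 4-bromophenyl group. No measurement in hand speaks to the reason for these steps.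

Still open, on these data alone, is whether an amine or a carboxylic acid on the aryl ring, or a longer chain in place of the carbamoylamino link, would move the number beyond the scatter. Also open, as far as these compounds go, is how the same link behaves when it carries 3-fluorophenyl, which would complete the matched set with compound 1.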